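The source may report more compounds than this note shows. Statements on the series, on what has been measured and on what is new or still open speak of the compounds shown alone.

Of the compounds shown here, three sharing one core have been measured in a functional assay on MGC-803 cells (Homo sapiens) for inhibition, read by MTT assay, with a stated time of 72 h; a lower number here means a stronger inhibitor, a higher number a weaker inhibitor. Compound 1 `Cc1cc(Nc2cc(-c3ccccc3)[nH]n2)n2nc(SCc3c(Cl)cccc3Cl)nc2n1` gives 5280 nM. Compound 2 `Cc1cc(Nc2cc(-c3ccccc3)[nH]n2)n2nc(SCCc3ccccc3)nc2n1` gives 5620 nM in this assay. Among the measured compounds shown here, the single change between these two, a 1.1-fold higher number from compound 1 to compound 2 (0.03 log units; within the scatter), left the number where it was, with the whole shift inside the normal spread of repeated measurements. Compound 3 `Cc1ccc(Cn2ccc(Nc3cc(C)nc4nc(SCc5ccc(Br)cc5)nn34)n2)cc1` gives 7420 nM in this assay; this is the highest of the three numbers, yet the values of compound 2 and compound 1 sit so close to it that no order among the three can be claimed.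

Compound 4 `COc1ccc(Cn2ccc(Nc3cc(C)nc4nc(SCc5ccc(Br)cc5)nn34)n2)cc1` has not yet been measured. It differs from compound 3 in one place: methoxy in place of methyl on an aromatic carbon. The change sits on an aromatic carbon of a six-membered aromatic ring of carbon only. For the measured compounds named here, no measured step involves a methoxy or this ring, so the only guidance is the one step available, a 1.1-fold higher number from compound 1 to compound 2 (0.03 log units; within the scatter), in which swapping a group on the sulfur-bound chain moved the number by no more than the scatter. Compound 4 is therefore expected to give about 7400 nM in this assay, with a plausible range from 3500 nM to 16000 nM. The expected step of a 1.0-fold lower number from compound 3 to compound 4 (0.00 log units; within the scatter) is none beyond the scatter.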

Compound 4, half-maximal inhibitory concentration: 12600 nM
The estimate for compound 4 lay 1.7-fold (0.23 log units) below the measured number; measured number inside the range.
By their numbers in this assay, from the lowest: compounds 1, 2, 3 and 4 (each within the scatter of the next, the first and the last beyond it).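

In this assay the swap of 4-methylbenzyl to 4-methoxybenzyl gives a 1.7-fold higher number from compound 3 to compound 4 (0.23 log units; within the scatter) and thus provides a measured step on the six-membered aromatic ring of carbon only, whereas the earlier step lay on the sulfur-bound chain. Exchanging methyl for methoxy at this place, para to a large group, adds one oxygen and one hydrogen-bond acceptor, yet the shift cannot be told apart from the ordinary spread of repeated measurements, so this pair gives no sign that the number responds to the swap. The data at hand offer no explanation for this result.

Among the compounds shown, only methyl and methoxy occupy this place, so it remains open whether an amine, a carboxylic acid, a fluorine atom or a longer chain there would move the number beyond the scatter. Among the compounds shown here, it is also open whether the same swap would behave alike in compounds carrying the phenyl group found in compound 1 and compound 2, where no such pair is available.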